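The compounds below may be only part of what the source reports. "The series", "measured", "known", "first", "only" and "open" are said of these compounds alone.

Compound 1 `COC(=O)c1ccc(OCCCCOc2ccc(C(=O)CC(C)C)c(O)c2C)cc1`: 22.7%
Compound 2 `Cc1c(OCCCCOc2ccc(F)c(C(=O)O)c2)ccc(C(=O)CC(C)C)c1C`: 13.8%

In an assay on HEK293 cells for positive allosteric modulation of metabotropic glutamate receptor 3 (Rattus norvegicus), read by thallium flux, with a stated time of 2.5 min (a lower number here means a smaller maximal response, a higher number a larger maximal response), compound 1 gives 22.7% and compound 2 gives 13.8%. Compound 2 holds the lower of the two numbers, yet its gap to compound 1 lies within the usual scatter, so the two cannot be told apart on these data. Within the data shown here, they differ in more than one place, so no single step between them is computed. Compound 3 `COC(=O)c1ccc(OCCCCOc2ccc(C(=O)CC(C)C)c(C)c2C)cc1` has not yet been measured. It differs from compound 2 in one place: 4-(methoxycarbonyl)phenyl in place of 3-carboxy-4-fluorophenyl on an oxygen on a saturated carbon. Compound 3 is expected to land near compound 1, because compound 1 gives 22.7% and carries the same 4-(methoxycarbonyl)phenyl group. The expected step is therefore small, upward if anything, and likely not beyond the scatter: a number 6.2 percentage points higher from compound 2 to compound 3 (within the scatter). Compound 3 is estimated at 20%, within a range from 8% to 35%.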

Compound 3, largest response reached (reported as percent of maximum), in percent of the reference or control that the assay uses: 27.3%
Estimate against measurement, compound 3: 7.3 percentage points below, and the stated range covers the measured number.
By their numbers in this assay, from the lowest: compounds 2, 1 and 3 (each within the scatter of the next, the first and the last beyond it).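

In this assay, 4-(methoxycarbonyl)phenyl in place of 3-carboxy-4-fluorophenyl on an oxygen on a saturated carbon gives a number 13.5 percentage points higher from compound 2 to compound 3 (beyond the scatter) and so shows, in a single change, that the group at this place can move the maximal response. Methyl in place of hydroxy on an aromatic carbon gives a number 4.6 percentage points higher from compound 1 to compound 3 (within the scatter) and so does not separate this pair on these data. Nothing at hand accounts for either step.

From the compounds shown here alone, the swap at the oxygen alters the ring's fluorine and its carboxylic acid together, so it stays open which of these differences carries the step. Also open, going by these compounds, is how a 4-carboxyphenyl group, a plain phenyl group or an amide at this place would read, and what a longer chain would do.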